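Swapping a chloro for an acetyl at the far end

The compounds below may be only part of what the source reports. "The series", "measured", "known", "first", "only" and "open" are said of these compounds alone.

Measured so far:
compound 1 `COc1ccc(-c2ccc(OCc3cc(C(=O)O)oc3C)cc2)cc1OC` — 2800 nM
compound 2 `Cc1oc(C(=O)O)cc1COc1ccc(-c2ccc(Cl)cc2)cc1` — 1000 nM

Two compounds share a common core and differ at the end of the biaryl. In an assay on cells for displacement of a labelled ligand from prostaglandin E2 receptor EP4 subtype (Homo sapiens), read by scintillation counting (on this read-out lower numbers stand for stronger inhibition and higher numbers for weaker inhibition), compound 2 gives the lowest of the two numbers; compound 1 gives a higher number, and that gap lies beyond the usual scatter. Compound 3 `CC(=O)c1ccc(-c2ccc(OCc3cc(C(=O)O)oc3C)cc2)cc1` is not yet measured. It differs from compound 2 by acetyl in place of chloro on an aromatic carbon. Among the measured compounds shown here, no measured pair shows this change, so the step from a chloro to an acetyl is expected to be modest: a 1.5-fold higher number from compound 2 to compound 3 (0.18 log units; within the scatter) is estimated to lie within the scatter, with a slight lean toward a weaker number. Compound 3 is estimated at 1500 nM, within a range of 500 nM to 5000 nM.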

Compound 3, inhibition constant: 150 nM
Estimate against measurement, compound 3: 10-fold (1.00 log units) above; the measured number lies below the stated range.
By their numbers in this assay, from the lowest: compound 3; then compound 2; then compound 1.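

In this assay, acetyl in place of chloro on this aromatic carbon gives a 6.7-fold lower number from compound 2 to compound 3 (0.82 log units; beyond the scatter). The earlier compounds shown here did not isolate a single change at this position; this pair shows that one swap here can shift binding beyond the scatter, with acetyl, which brings a hydrogen-bond acceptor, giving the lower number. Nothing shown accounts for the size of this step.

Going by these compounds, it remains open whether a nitrile, an amide or a longer ketone chain on this carbon would give a lower or higher number than acetyl. On these data alone, whether the same swap would have a similar effect on a different core also remains open.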